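The source may report more compounds than this note shows. Statements on the series, on what has been measured and on what is new or still open speak of the compounds shown alone.

The three measured compounds, all read in a functional assay on CHO-K1 cells with Glucose-dependent insulinotropic receptor (Homo sapiens) as the target, read by a luciferase reporter, with a stated time of 5 h; on this read-out higher numbers stand for larger maximal responses and lower numbers for smaller maximal responses:
compound 1, `CC(C)OC(=O)N1CCC(Oc2ncnc3c2CCN3c2ccc(S(C)(=O)=O)cc2)CC1`, gives 154%;
compound 2, `COC(=O)N1CCC(Oc2ncnc3c2CCN3c2ccc(S(C)(=O)=O)cc2F)CC1`, gives 119%;
compound 3, `CCCCOC(=O)N1CCC(Oc2ncnc3c2CCN3c2ccc(S(C)(=O)=O)cc2F)CC1`, gives 131%.

Compound 1 stands highest of the three numbers; compound 3 comes nearest, and compound 2 lies furthest below, both gaps beyond the scatter.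

Compound 4, `CC(C)OC(=O)N1CCC(Oc2ncnc3c2CCN3c2ccc([S+]([O-])N(C)C)cc2)CC1`, differs from compound 1 in one place: a group of 5 heavy atoms (2 carbon, 1 nitrogen, 1 oxygen, 1 sulfur; no ring) in place of a group of 4 heavy atoms (1 carbon, 2 oxygen, 1 sulfur; no ring), on an aromatic carbon. Among the compounds with values here, the only measured step, a number 12 percentage points higher from compound 2 to compound 3 (beyond the scatter), changes the chain on the oxygen next to the carbonyl group and leaves the methylsulfonyl untouched, so it says nothing about an exchange at the aromatic ring. Within the data shown here, no measured pair shows what replacing the methylsulfonyl does in this assay. With no guide from the data, the expectation is an uncertain one: a modest fall is estimated, a number 24 percentage points lower from compound 1 to compound 4 (beyond the scatter), with a wide range around it. Compound 4 is therefore expected to reach about 130%, somewhere between 85% and 170%.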

Compound 4, largest response reached (reported as percent of maximum), in percent of the reference or control that the assay uses: 128%
For compound 4 the middle estimate is 2 percentage points above the measured one; low and high end bracket the measured number.
By their numbers in this assay, from the lowest: compounds 2, 4 and 3 (each within the scatter of the next, the first and the last beyond it); then compound 1.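

Within the data shown here, this is the first measured change at the aromatic carbon that carries the methylsulfonyl: in this assay, the new sulfur-and-nitrogen group gives a number 26 percentage points lower from compound 1 to compound 4 (beyond the scatter), so the maximal response depends on which group sits here. The response does not depend on the exact methylsulfonyl group alone, though, since compound 4 still gives 128% in the same test. The leaving and entering groups have equal counts of hydrogen-bond donors and acceptors, and nothing available explains the drop.

From the compounds shown here alone, it remains open whether a nitrile, a carboxylic acid or an amine at this ring carbon would give a higher or lower response. Going by these compounds, it is also open whether the same exchange would give a similar step in the fluorine-bearing compound 2 and compound 3.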